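The compounds below may be only part of what the source reports. "The series", "measured", "known", "first", "only" and "open" are said of these compounds alone.

Of the compounds shown here, two have so far been measured in an assay on cell membranes for binding affinity to 2-oxoglutarate receptor 1 (Rattus norvegicus), read by radioligand binding; on this read-out higher numbers stand for weaker inhibition and lower numbers for stronger inhibition. Compound 1 `CCCCCCCCNC(=O)[C@H]1OC(n2cnc3c(N)ncnc32)[C@H](O)[C@@H]1O` carries an octyl chain on its amide nitrogen, and in this assay compound 1 gives 21 nM. Compound 2 `C[C@H]1CC[C@@H](NC(=O)[C@H]2O[C@@H](n3cnc4c(N)ncnc43)[C@H](O)[C@@H]2O)CC1` carries a ring-bearing group at that nitrogen instead, and in this assay compound 2 gives 55.6 nM. Of these two numbers compound 1 has the lower one, and the gap to compound 2 is beyond the usual scatter, so compound 1 is the stronger binder of the pair.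

Compound 3 `CC(C)CONC(=O)[C@H]1OC(n2cnc3c(N)ncnc32)[C@H](O)[C@@H]1O` has not been measured. It differs from compound 1 in a single place: isobutoxy in place of octyl on an amide-type nitrogen. For the measured compounds named here, no measured pair shows a change of this kind, so there is nothing to read its effect from directly. Going by the values given here, the only guidance is that both measured compounds carry a carbon group on the amide nitrogen and that compound 1, with the octyl chain, stands at the stronger end. A weaker result is expected for compound 3, with a step of a 5.7-fold higher number from compound 1 to compound 3 (0.76 log units; beyond the scatter). The estimate for compound 3 is 120 nM. At the low end compound 3 is expected at 30 nM. At the high end compound 3 is expected at 600 nM.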

Compound 3, inhibition constant: 20 nM
For compound 3 the middle estimate is 6.0-fold (0.78 log units) above the measured one; measured number below the stated range.
By their numbers in this assay, from the lowest: compounds 3 and 1 (each within the scatter of the next); then compound 2.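

In this assay, replacing octyl with isobutoxy on the amide-type nitrogen gives a 1.1-fold lower number from compound 1 to compound 3 (0.02 log units; within the scatter), so the two compounds cannot be told apart on this read-out. This shows that, at least for this pair, the full octyl chain is not required to keep the number in this range: isobutoxy, with 5 heavy atoms in place of 8 and one of them an oxygen, serves equally well at this nitrogen. No supporting evidence is available to explain why the two groups give matching results.

The compounds shown do not separate the effect of the oxygen from that of the shorter, branched carbon part, and isobutyl on the same nitrogen would differ from compound 3 only by that oxygen. They also leave open how small the group at this nitrogen can become, as with methoxy, and whether a carboxylic acid or an amine at the end of the chain would leave the number unchanged.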